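The source may report more compounds than this note shows. Statements on the series, on what has been measured and on what is new or still open speak of the compounds shown alone.

Three compounds have been measured in a functional assay on HCT-116 cells (Homo sapiens) for inhibition, read by sulforhodamine B assay, with a stated time of 48 h, tested at 50 uM; on this read-out higher numbers stand for more inhibition of growth at the one concentration tested and lower numbers for less inhibition of growth:

Compound 1, `COc1cc(/C=C/C(=O)/C=C/c2cc(OC)c(OC)c(OC)c2)ccc1OCc1cn(CCOc2cc(=O)oc3ccccc23)nn1`, gives 89%.
Compound 2, `COc1ccccc1/C=C/C(=O)/C=C/c1ccc(OCc2cn(CCCCOc3cc(=O)oc4ccccc34)nn2)c(OC)c1`, gives 43%.
Compound 3, `COc1cc(/C=C/C(=O)/C=C/c2cccc3ccccc23)ccc1OCc1cn(CCCCOc2cc(=O)oc3ccccc23)nn1`, gives 56%.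

Compound 3 stands second highest of the three numbers: compound 2 lies nearest, and compound 1 furthest, with both gaps beyond the scatter. Compound 4, `COc1cc(/C=C/C(=O)/C=C/c2ccco2)ccc1OCc1cn(CCCCOc2cc(=O)oc3ccccc23)nn1`, has not yet been measured. It differs from compound 3 in one place: furan-2-yl in place of naphthalen-1-yl on a double-bonded chain carbon bound to a double-bonded chain carbon.

Among the compounds with values here, only one measured step touches this position, a number 13 percentage points higher from compound 2 to compound 3 (beyond the scatter), and it exchanges a different group, 2-methoxyphenyl for naphthalen-1-yl, so it shows that swapping the aryl group at this carbon can shift the number modestly, without telling which way a furan-2-yl would move it. Within the data shown here, no compound with a five-membered ring at this place has been measured. The change from compound 3 to compound 4 is therefore expected to give a step of a number 6 percentage points lower from compound 3 to compound 4 (within the scatter) in this assay, which lies within the scatter. Compound 4 is estimated to reach 50%, in a range from 25% to 75%.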

Compound 4, percent growth inhibition at one concentration: 47%
Beside the measured number, compound 4's estimate is 3 percentage points above it, within the range that was stated.
By their numbers in this assay, from the lowest: compounds 2, 4 and 3 (each within the scatter of the next, the first and the last beyond it); then compound 1.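

In this assay, the step of a number 9 percentage points lower from compound 3 to compound 4 (within the scatter) shows that a furan-2-yl group, with fewer heavy atoms, can replace the naphthalen-1-yl group without a change that can be told from the scatter. The step of a number 4 percentage points higher from compound 2 to compound 4 (within the scatter) gives the same kind of reading against 2-methoxyphenyl, so a five-membered aromatic ring with 1 hetero atom is tolerated on this carbon, and the number cannot be separated from that of either six-membered-ring compound. Nothing measured here explains why these groups give such close numbers.

From the compounds shown here alone, whether a thiophen-2-yl group, or a phenyl group carrying an amine or a carboxylic acid, would move the number beyond the scatter remains open. A single tested concentration also leaves open how compound 2, compound 3 and compound 4 would compare at other concentrations.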